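The source may hold more compounds than are shown below. What is called first, only, known or untested is meant among the compounds shown, and "the series" means these compounds.

Working notes on the series

Three compounds carry numbers in a functional assay on HT-29 cells (Homo sapiens) for cytotoxicity, read by XTT assay, with a stated time of 72 h; on this read-out lower numbers stand for stronger inhibition and higher numbers for weaker inhibition. Compound 1 `CC(=O)c1c(O)cc(O)cc1OC/C=C(\C)CC/C=C(\C)CCC=C(C)C` gives 31000 nM in this assay. Compound 3 `CC(C)=CCC/C=C(\C)Cc1c(O)cc(O)c2c(=O)c(OC/C=C(\C)CCC=C(C)C)c(-c3ccc(O)cc3)oc12` gives 30000 nM in this assay, and its value and that of compound 1 sit within the scatter of each other, so no order between them can be read. Compound 2 `CCCCCCCC/C=C\CCCCCCCCOc1cc(O)c(C(C)=O)c(OCCCCCCCC/C=C\CCCCCCCC)c1` is reported only as a limit in this assay, > 100000 nM; the relevant line is the limit of > 100000 nM in this assay, at which 1 of the 3 values shown sits. Among the measured compounds shown here, no pair of the measured compounds differs in a single place, so no measured step is available to lean on.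

Compound 4 `CC(C)=CCC/C=C(\C)Cc1c(O)cc(O)c2c(=O)c(O)c(-c3ccc(O)cc3)oc12` is the not yet measured member. It differs from compound 3 in one place: hydrogen in place of 3,7-dimethylocta-2,6-dien-1-yl on an oxygen on an aromatic ring. For the measured compounds named here, the two numbered values shown lie close together, and the one change of this kind that can be compared, the loss of one chain while a second chain is kept, has no counterpart among the measured pairs. The step from compound 3 to compound 4 in this assay is therefore expected to be small and not beyond the scatter, with the number for compound 4 perhaps a little higher; the expected step is a 1.5-fold higher number from compound 3 to compound 4 (0.18 log units; within the scatter). For compound 4 the estimate in this assay is 45000 nM, with a range from 12000 nM to 110000 nM.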

Compound 4, half-maximal inhibitory concentration: 30000 nM
The estimate for compound 4 lay 1.5-fold (0.18 log units) above the measured number; the measured number falls inside the stated range.
By their numbers in this assay, from the lowest: compounds 3, 4 and 1 (each within the scatter of the next). At a limit, above all of these: compound 2.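

The series now has its first measured single-place step in this assay: hydrogen in place of 3,7-dimethylocta-2,6-dien-1-yl on an oxygen on an aromatic ring gives no change at the digits printed from compound 3 to compound 4 (within the scatter) in this comparison. On this oxygen, then, a chain of 10 heavy atoms with 2 double bonds and a bare hydroxy group cannot be told apart by this read-out, so the chain is not needed for the number seen here. No measured property among the data gives a reason for this result.

Still open, going by these compounds, is whether other groups on this oxygen, such as a methyl group, a longer chain or a chain ending in an amine or a carboxylic acid, would move the number beyond the scatter, and whether the chain that compound 3 and compound 4 share matters at all. Among the compounds shown here, compound 2 is reported only as a limit and is joined to the other compounds by no single-place step, so it says nothing yet about this position.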